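Permeability notes on a chlorophenylsulfonamide series with nitrile side chains

A few compounds are considered here, and "the series" means these few. Any claim that something is new, unique, unknown or untested is made for them only; others in the source may bear on it.

Measured so far in an ADME assay on MDCKII-LE cells (Canis lupus familiaris) for permeability; a higher number here means that the compound crosses the layer faster, a lower number that the compound crosses the layer more slowly:
compound 1 `N#CCCCN([C@H](CCC(F)(F)F)C(N)=O)S(=O)(=O)c1ccc(Cl)cc1`: 27.6 10^-6 cm/s
compound 2 `N#CCCCCN([C@H](CCC(F)(F)F)C(N)=O)S(=O)(=O)c1ccc(Cl)cc1`: 24 10^-6 cm/s
compound 3 `N#C[C@H]1C[C@H](CN([C@H](CCC(F)(F)F)C(N)=O)S(=O)(=O)c2ccc(Cl)cc2)C1`: 24.9 10^-6 cm/s

Compound 1 carries the highest of the three numbers in this assay, but neither gap separates it from the others: a 1.1-fold lower number from compound 1 to compound 3 (0.04 log units; within the scatter) and a 1.2-fold lower number from compound 1 to compound 2 (0.06 log units; within the scatter) both fall within the scatter, so the three compounds are to be read as indistinguishable on this read-out, with no order among them.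

Compound 4 `C[C@]1(C#N)C[C@H](CN([C@H](CCC(F)(F)F)C(N)=O)S(=O)(=O)c2ccc(Cl)cc2)C1` has not yet been measured. Relative to compound 1 the change is 3-cyano-3-methylcyclobutyl in place of 2-cyanoethyl on a saturated chain carbon bound to a sulfonamide nitrogen.

Within the data shown here, two measured steps bear on this. The first, a 1.2-fold lower number from compound 1 to compound 2 (0.06 log units; within the scatter), lengthens the nitrile-bearing chain; the second, a 1.1-fold lower number from compound 1 to compound 3 (0.04 log units; within the scatter), closes the chain into the cyanocyclobutyl ring that compound 4 also carries. A third, a 1.0-fold higher number from compound 2 to compound 3 (0.02 log units; within the scatter), is likewise flat. Every variation of the nitrile-bearing group so far has left the apparent permeability where it was. The expectation for compound 4 is therefore no step beyond the scatter: a 1.1-fold lower number from compound 1 to compound 4 (0.03 log units; within the scatter).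

Compound 4 is estimated at 26 10^-6 cm/s in this assay, with an expected range from 15 10^-6 cm/s to 45 10^-6 cm/s.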

Compound 4, apparent permeability: 21.8 10^-6 cm/s
The estimate for compound 4 lay 1.2-fold (0.08 log units) above the measured number; the measured number falls inside the stated range.
By their numbers in this assay, from the lowest: compounds 4, 2, 3 and 1 (each within the scatter of the next).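

In this assay, the change at this place, on a saturated chain carbon bound to a sulfonamide nitrogen, brings in 3-cyano-3-methylcyclobutyl with 7 heavy atoms for the 4 of 2-cyanoethyl, and even this change gives no step beyond the scatter (a 1.3-fold lower number from compound 1 to compound 4 (0.10 log units; within the scatter)). Among these compounds, the methyl group on the cyclobutyl ring, a feature not varied among the earlier compounds, can be read on its own and also stays within the scatter (a 1.1-fold lower number from compound 3 to compound 4 (0.06 log units; within the scatter)), as does the comparison with the open 3-cyanopropyl chain (a 1.1-fold lower number from compound 2 to compound 4 (0.04 log units; within the scatter)), so all the variations at this place on the four compounds leave the read-out flat. No measurement shown offers an explanation for this flat read-out.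

On these data alone, all four compounds keep a nitrile on this side chain, so it remains open whether an amine, a carboxylic acid or a hydroxyl group at the same place would also stay within the scatter in this assay. As far as these compounds go, the rest of the core of compound 1 is unchanged throughout, so it is also open how the read-out would respond to a change there, for instance to a different group in place of the chlorine or the primary amide.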